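Compound 4 swaps methyl for 2-aminophenyl

The source may report more compounds than this note shows. Statements on the series, on what has been measured and on what is new or still open speak of the compounds shown alone.

Of the compounds shown here, three have been measured in a functional assay on MCF7 cells (Homo sapiens) for cytotoxicity, read by MTT assay, with a stated time of 48 h; on this read-out higher numbers stand for weaker inhibition of growth and lower numbers for stronger inhibition of growth: compound 1 `OC[C@H]1O[C@@H](n2cnc3cc(F)c(F)cc32)[C@H](O)[C@@H]1O` (57900 nM), compound 2 `Fc1ccccc1-c1nc2cc(Cl)c(Cl)cc2[nH]1` (47500 nM) and compound 3 `CCn1c(C(F)(F)F)nc2cc(Cl)c(Cl)cc21` (72900 nM). These values lie within the usual scatter of one another, so compound 3 stands level with the other two. Compound 4 `Nc1ccccc1Cn1c(C(F)(F)F)nc2cc(Cl)c(Cl)cc21` has 2-aminophenyl in place of methyl on a saturated chain carbon bound to an aromatic nitrogen. Among the measured compounds shown here, no two measured compounds differ in one place, so nothing measured shows what a change like this does in this assay, and any expectation is loose. A modest move towards stronger inhibition of growth is expected, an estimated step (a 2.4-fold lower number from compound 3 to compound 4 (0.39 log units; beyond the scatter)) whose range still includes no real change. Compound 4 is estimated at 30000 nM (range 8000 nM to 80000 nM).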

Compound 4, concentration for 50% growth inhibition: 55600 nM
The estimate for compound 4 lay 1.9-fold (0.27 log units) below the measured number; low and high end bracket the measured number.
By their numbers in this assay, from the lowest: compounds 2, 4, 1 and 3 (each within the scatter of the next).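

Among the compounds shown here, replacing methyl with 2-aminophenyl on a saturated chain carbon bound to an aromatic nitrogen gives a 1.3-fold lower number from compound 3 to compound 4 (0.12 log units; within the scatter) in this assay as the first one-place comparison in this set. This position therefore accepts the larger group, with its added aromatic ring, without a change in growth inhibition beyond the scatter. No evidence here explains this outcome. The compounds shown leave open whether the amine on the new ring matters, since plain phenyl does not appear among them. They also leave open whether a carboxylic acid on that ring, or a longer chain at this place, would shift the number beyond the scatter.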